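Swapping the Amide Aryl Group: What Compound 4 May Tolerate

This account rests on a few compounds, and the source may have more. Where it says the series, first, only, none or still open, it means among the compounds named here.

Of the compounds shown here, three sharing one core have been tested in an ADME assay on Huh-7 cells (Homo sapiens) for cytotoxicity, with a stated time of 3 days; a lower number here means that less compound is tolerated, a higher number that more compound is tolerated. Compound 1 `O=C(Nc1ccccc1O)c1c(NO)cc(-c2ccccc2)oc1=O` gives 14000 nM in this assay, and compound 2 `O=C(NC1CCCCC1)c1c(NO)cc(-c2ccc(F)cc2)oc1=O` gives 11400 nM. Compound 3 `O=C(Nc1ccc(F)cc1)c1c(NO)cc(-c2cccs2)oc1=O` reaches only a limit of the assay in this assay, > 20000 nM. Among the values shown, compound 3 alone sits at that boundary (the limit of > 20000 nM in this assay, at which 1 of the 3 values shown sits). Compound 4 `Cc1ccccc1NC(=O)c1c(NO)cc(-c2cccs2)oc1=O` is not yet measured; it differs from compound 3 in one place: 2-methylphenyl in place of 4-fluorophenyl on an amide-type nitrogen. Within the data shown here, no step between two measured compounds is known, so the change from compound 3 to compound 4 is expected to move this assay little, if at all, beyond the scatter, as an at least 1.1-fold lower number from compound 3 to compound 4 (0.04 log units; that floor lies within the scatter). Compound 4 is estimated at 18000 nM, between 9000 nM and 40000 nM, with a fair chance that the assay again reports only a limit.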

Compound 4, half-maximal cytotoxic concentration: > 20000 nM
Compound 4 gave a limit, no number (the forecaster's own chance of this, stated with the estimate: 45%); at least 1.1-fold (0.04 log units) between middle value and limit.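

Compound 3 and compound 4 both stop at a limit in this assay, so no step can be read between them: the limit of > 20000 nM in this assay, at which 2 of the 4 values shown sit.

As far as these compounds go, whether 2-methylphenyl in place of 4-fluorophenyl on an amide-type nitrogen changes tolerance at all remains open.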